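Notes on the step from compound 3 to compound 4

The source may report more compounds than this note shows. Statements on the series, on what has been measured and on what is new or still open speak of the compounds shown alone.

Measured so far in a functional assay on MCF7 cells (Homo sapiens) for inhibition, read by CCK-8 assay, with a stated time of 48 h; a higher number here means a weaker inhibitor of growth, a lower number a stronger inhibitor of growth
- compound 1 `CN1CCN(c2ccc(Nc3ncc(Cl)c(Nc4ccccc4)n3)nc2)CC1` gives 51800 nM
- compound 2 `CN1CCN(c2ccc(Nc3ncc(Cl)c(NCc4ccco4)n3)nc2)CC1` gives 21300 nM
- compound 3 `CC(C)c1ccc(Nc2nc(Nc3ccc(N4CCN(C)CC4)cn3)ncc2Cl)cc1` gives 1880 nM

Compound 3 has the lowest number of the three, and its gaps to both others lie beyond the scatter. Compound 4 `Cc1cc(C)c(Nc2nc(Nc3ccc(N4CCN(C)CC4)cn3)ncc2Cl)c(C)c1`, not yet measured, carries 2,4,6-trimethylphenyl in place of 4-isopropylphenyl on a nitrogen on an aromatic ring and has the same atoms, joined differently.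

The most relevant evidence is a 28-fold lower number from compound 1 to compound 3 (1.44 log units; beyond the scatter), a large step that leads to the 4-isopropylphenyl group given up in compound 4. The large 11-fold lower number from compound 2 to compound 3 (1.05 log units; beyond the scatter) also bears on the change, while the modest 2.4-fold lower number from compound 1 to compound 2 (0.39 log units; beyond the scatter) bears on it less. Among the compounds with values here, no measured compound carries 2,4,6-trimethylphenyl, so these steps give no direct measure of it. Compound 4 is expected to keep part of the drop seen for compound 3 relative to compound 1, but not all of it. The expected change in this assay is therefore a moderate rise, estimated as a 2.9-fold higher number from compound 3 to compound 4 (0.47 log units; beyond the scatter), with a fall not excluded. For compound 4 the estimated value is 5500 nM, with an expected range from 1800 nM to 17000 nM (both ends estimated).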

Compound 4, concentration for 50% growth inhibition: 9470 nM
Beside the measured number, compound 4's estimate is 1.7-fold (0.24 log units) below it; low and high end bracket the measured number.
By their numbers in this assay, from the lowest: compound 3; then compound 4; then compound 2; then compound 1.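

In this assay, rearranging the same carbon count from 4-isopropylphenyl into 2,4,6-trimethylphenyl on the nitrogen gives a 5.0-fold higher number from compound 3 to compound 4 (0.70 log units; beyond the scatter), so at this position the outcome depends on how the carbons are joined and not only on how many are present. The new group still keeps part of the gain over the unsubstituted ring, with a 5.5-fold lower number from compound 1 to compound 4 (0.74 log units; beyond the scatter) set against the larger 28-fold lower number from compound 1 to compound 3 (1.44 log units; beyond the scatter), and it also improves on the furan-bearing group, with a 2.2-fold lower number from compound 2 to compound 4 (0.35 log units; beyond the scatter). No measurement is available that explains why the two isomeric groups differ.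

The compounds shown leave open which of the three methyl groups in 2,4,6-trimethylphenyl accounts for the rise relative to compound 3, and whether a single methyl group on the phenyl ring would behave more like 4-isopropylphenyl. They also leave open how a tert-butyl group, a methoxy group or an amine on that ring would compare with the isopropyl group of compound 3.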